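Hydroxy to Trifluoromethyl on the Shared Core

A few compounds are considered here, and "the series" means these few. Any claim that something is new, unique, unknown or untested is made for them only; others in the source may bear on it.

Two compounds share a core, differing only in one group on an outer aromatic ring. Compound 1 `COc1cccc(C#Cc2ccccc2C#CCCCCO)c1` carries a methoxy group, and in a functional assay on DU-145 cells (Homo sapiens) for cytotoxicity (a higher number here means a weaker inhibitor of growth, a lower number a stronger inhibitor of growth), compound 1 gives 4100 nM. Compound 2 `OCCCCC#Cc1ccccc1C#Cc1cccc(O)c1` carries a hydroxy group instead, and in this assay compound 2 gives 17400 nM, the higher of the two numbers, with compound 1 as its nearest neighbour. Among the compounds with values here, the only measured step, a 4.2-fold higher number from compound 1 to compound 2 (0.63 log units; beyond the scatter), shows that swapping the group at this position moves the result by a modest amount.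

Compound 3 `OCCCCC#Cc1ccccc1C#Cc1cccc(C(F)(F)F)c1` is compound 2 with trifluoromethyl in place of hydroxy on an aromatic carbon. Within the data shown here, no measured step covers this particular exchange; the one step known shows only that the position responds to change. Compound 1 likewise has no hydrogen-bond donor at that site and gives 4100 nM, so the expectation leans toward the lower end of the two measured numbers. The step from compound 2 to compound 3 is therefore expected to be a modest decrease, a 3.5-fold lower number from compound 2 to compound 3 (0.54 log units; beyond the scatter). Compound 3 is estimated at 5000 nM, with a range from 1500 nM to 18000 nM.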

Compound 3, concentration for 50% growth inhibition: 15300 nM
Compound 3: the middle estimate sits 3.1-fold (0.49 log units) below what was measured; the measured number falls inside the stated range.
By their numbers in this assay, from the lowest: compound 1; then compounds 3 and 2 (each within the scatter of the next).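

In this assay the exchange gives a 1.1-fold lower number from compound 2 to compound 3 (0.06 log units; within the scatter) and so shows that this position does not separate hydroxy from trifluoromethyl, even though the two groups differ in their heavy atoms and hydrogen-bond donors. The second comparison, a 3.7-fold higher number from compound 1 to compound 3 (0.57 log units; beyond the scatter), sets methoxy apart from trifluoromethyl as well, leaving compound 1 with the lowest number of the three and showing that the absence of a hydrogen-bond donor at this site is not enough on its own to match compound 1 at 4100 nM in this series. No measurement available here gives a reason for the difference between methoxy and the other two groups.

The compounds shown leave open whether the lower number belongs to methoxy in particular or would also appear with a close relative, such as ethoxy, which has a longer chain on the same oxygen. They also leave open how the same position would respond to a differently built group such as an amine or a carboxylic acid, and whether any such group could go beyond the number of compound 1.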